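This account rests on a few compounds, and the source may have more. Where it says the series, first, only, none or still open, it means among the compounds named here.

Of the compounds shown here, three sharing one core have been tested in a functional assay on MGC-803 cells (Homo sapiens) for inhibition, read by MTT assay, with a stated time of 72 h; on this read-out higher numbers stand for weaker inhibition and lower numbers for stronger inhibition. Compound 2 `Cc1cc(Nc2cc(-c3ccccc3)[nH]n2)n2ncnc2n1` carries a hydrogen where the others carry a sulfur-linked arm, and compound 2 gives 21700 nM. Compound 3 `Cc1cc(Nc2cc(-c3ccccc3)[nH]n2)n2nc(SCc3csc4ccccc34)nc2n1` gives 2280 nM, placing it at the low end of the three numbers; the step of a 9.5-fold lower number from compound 2 to compound 3 (0.98 log units; beyond the scatter) lies beyond the scatter. Compound 1 `Cc1cc(Nc2ccn(Cc3cccc4ccccc34)n2)n2nc(SCc3ccc(Br)cc3)nc2n1` carries a different arm, and compound 1 gives 3240 nM, within the scatter of compound 3. Compound 4 `Cc1cc(Nc2cc(-c3ccccc3)[nH]n2)n2nc(SCc3ccc(C(F)(F)F)cc3)nc2n1` differs from compound 3 by 4-(trifluoromethyl)phenyl in place of 1-benzothiophen-3-yl on a saturated chain carbon bound to a sulfur. Within the data shown here, no measured step covers this exchange; compound 1 and compound 3 only show that two different arms give numbers within the scatter of each other. The step from compound 3 to compound 4 is therefore expected to be a 1.3-fold higher number from compound 3 to compound 4 (0.12 log units; within the scatter), within the scatter. Compound 4 is expected to give 3000 nM, between 1200 nM and 8000 nM.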

Compound 4, half-maximal inhibitory concentration: 3520 nM
For compound 4 the middle estimate is 1.2-fold (0.07 log units) below the measured one, within the range that was stated.
By their numbers in this assay, from the lowest: compounds 3, 1 and 4 (each within the scatter of the next); then compound 2.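

In this assay, placing 4-(trifluoromethyl)phenyl in place of 1-benzothiophen-3-yl on the saturated chain carbon bound to a sulfur gives a 1.5-fold higher number from compound 3 to compound 4 (0.19 log units; within the scatter). A group with two aromatic rings and a sulfur and a group with one aromatic ring and three fluorine atoms therefore read alike at this position. No available evidence explains this result. On these data alone, it remains open whether an arm ending in an amine or a carboxylic acid, or a longer chain on the sulfur, would give a similar number.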